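Swapping the sulfamoyl group for a nitrile on a shared core

The compounds below may be only part of what the source reports. "The series", "measured", "known", "first", "only" and "open" are said of these compounds alone.

Of the compounds shown here, three with a shared core have been measured in a functional assay on U-937 cells (Homo sapiens) for antiproliferative activity, read by CCK-8 assay, with a stated time of 72 h; on this read-out higher numbers stand for weaker inhibition and lower numbers for stronger inhibition. Compound 1 `Cc1cc(Nc2cc(N3CCN(C)CC3)nc(Nc3ccc(S(N)(=O)=O)cc3)n2)n[nH]1` gives 100 nM, the highest of the three numbers. Compound 2 `Cc1cc(Nc2cc(N3CCN(C)CC3)nc(Nc3ccc(Cl)cc3)n2)n[nH]1` gives 55.4 nM, and compound 3 `Cc1cc(Nc2cc(N3CCN(C)CC3)nc(Nc3cccc([N+](=O)[O-])c3)n2)n[nH]1` gives 25.2 nM. The step of a 1.8-fold lower number from compound 1 to compound 2 (0.26 log units; within the scatter) is small, whereas a 4.0-fold lower number from compound 1 to compound 3 (0.60 log units; beyond the scatter) and a 2.2-fold lower number from compound 2 to compound 3 (0.34 log units; beyond the scatter) are both modest.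

Compound 4 `Cc1cc(Nc2cc(N3CCN(C)CC3)nc(Nc3ccc(C#N)cc3)n2)n[nH]1` is not yet measured. It differs from compound 1 in one place: cyano in place of sulfamoyl on an aromatic carbon. Among the measured compounds shown here, the closest precedent is the step from compound 1 to compound 2, where a chloro group likewise replaced the sulfamoyl group on the same aromatic carbon and a 1.8-fold lower number from compound 1 to compound 2 (0.26 log units; within the scatter) stayed within the scatter. The change to compound 3 touched a different ring position and is less informative. On that basis, compound 4 is expected to show a number close to compound 1, perhaps slightly lower, as a 1.5-fold lower number from compound 1 to compound 4 (0.19 log units; within the scatter). The estimate for compound 4 in this assay is therefore 65 nM, with a likely range from 25 nM to 170 nM.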

Compound 4, half-maximal inhibitory concentration: 9.03 nM
Compound 4: the middle estimate sits 7.2-fold (0.86 log units) above what was measured, and the stated range ends above it.
By their numbers in this assay, from the lowest: compound 4; then compound 3; then compounds 2 and 1 (each within the scatter of the next).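

In this assay this aromatic carbon proves far more sensitive than the chloro compound suggested: cyano in place of sulfamoyl gives an 11-fold lower number from compound 1 to compound 4 (1.04 log units; beyond the scatter) and cyano in place of chloro gives a 6.1-fold lower number from compound 2 to compound 4 (0.79 log units; beyond the scatter) on the same carbon, so the identity of the replacing group matters a great deal here. The 4-cyanophenyl group also compares well with the 3-nitrophenyl group, with a 2.8-fold lower number from compound 3 to compound 4 (0.45 log units; beyond the scatter) in this set, which makes compound 4 the lowest of the four numbers. Nothing measured here explains this gain.

The compounds shown leave open whether a carboxylic acid or an amine on this aromatic carbon would give a number as low as that of compound 4. They also leave open whether the gain is specific to the nitrile or would also appear with an ethynyl group.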